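Two Anilinopyrimidines Measured, a Third Awaits Its Number

This account rests on a few compounds, and the source may have more. Where it says the series, first, only, none or still open, it means among the compounds named here.

Compound 1 `CNC(=O)c1ccccc1Oc1nc(Nc2cccc(C(C)C)c2)ncc1Br` gives 17500 nM in a functional assay on HL-60 cells (Homo sapiens) for antiproliferative activity, read by MTT assay, with a stated time of 24 h; on this read-out higher numbers stand for weaker inhibition and lower numbers for stronger inhibition. Compound 2 `COc1cc(Nc2ncc(Br)c(Oc3ccc([N+](=O)[O-])cc3F)n2)cc(OC)c1OC` gives 10900 nM in this assay, the lower of the two numbers, though its gap to compound 1 lies within the usual scatter. Compound 3 `COc1cc(Nc2ncc(Br)c(ONCCCN)n2)cc(OC)c1OC` carries (3-aminopropyl)amino in place of 2-fluoro-4-nitrophenyl on an oxygen on an aromatic ring. Going by the values given here, no comparable step between measured compounds exists, so the size of this change in this assay is unknown. Compound 3 is expected to show a modest move toward a higher number, a 2.0-fold higher number from compound 2 to compound 3 (0.30 log units; within the scatter), though a step within the scatter is also possible. Compound 3 is estimated at 22000 nM, within 6000 nM to 80000 nM.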

Compound 3, half-maximal inhibitory concentration: 21500 nM
Compound 3: middle estimate off by 1.0-fold (0.01 log units), on the high side; measured number inside the range.
By their numbers in this assay, from the lowest: compounds 2, 1 and 3 (each within the scatter of the next).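

Putting (3-aminopropyl)amino in place of 2-fluoro-4-nitrophenyl on an oxygen on an aromatic ring gives a 2.0-fold higher number from compound 2 to compound 3 (0.30 log units; within the scatter) in this assay. Going by these compounds alone, this is the first step that can be read at this position, and it shows that a group with no ring can take the place of the aromatic one without leaving the scatter. Nothing available explains this result. Open, from the compounds shown here alone, is how a longer chain, a carboxylic acid or an unsubstituted phenyl group would read at this place. Going by these compounds, whether any group here can move the number beyond the scatter also remains unknown.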